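Methylpyrrole bromides: N-methylation step carried to the chromone core

The source may report more compounds than this note shows. Statements on the series, on what has been measured and on what is new or still open speak of the compounds shown alone.

Measured so far in a functional assay on KB403 cells (Homo sapiens) for cytotoxicity, read by MTT assay, with stated times of 6 h and 48 h; on this read-out higher numbers stand for weaker inhibition and lower numbers for stronger inhibition:
- compound 1 `Cn1c(/C=C/C(=O)c2ccc[nH]2)cc(Br)c1Br` gives 600 nM
- compound 3 `O=c1cc(-c2cc(Br)c(Br)[nH]2)oc2ccccc12` gives 1280 nM
- compound 2 `O=C(/C=C/c1cc(Br)c(Br)[nH]1)c1ccc[nH]1` gives >= 100000 nM

For compound 2 the value is a limit of this assay, not a number; it sits at the limit of >= 100000 nM in this assay, at which 1 of the 3 values shown sits.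

Compound 2 and compound 1 share a core and differ by methyl in place of hydrogen on an aromatic nitrogen. The step is an at least 160-fold lower number from compound 2 to compound 1 (2.22 log units; beyond the scatter); its size is known only as a bound because the limit of >= 100000 nM in this assay, at which 1 of the 3 values shown sits, is where compound 2 sits.

Compound 3 carries a different core; the difference between the core of compound 2 and the core of compound 3 is not broken down here. Among the two numbers in this assay, compound 3 has the higher one, with compound 1 nearest.

Compound 4 `Cn1c(-c2cc(=O)c3ccccc3o2)cc(Br)c1Br` is not yet measured. It differs from compound 3 by methyl in place of hydrogen on an aromatic nitrogen. This is the same kind of change as from compound 2 to compound 1, but the surroundings differ: in compound 1 the methylated nitrogen sits next to the ring atom that bears a group of 9 heavy atoms, in compound 4 next to the ring atom that bears a large group.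

The single measured case of this change, an at least 160-fold lower number from compound 2 to compound 1 (2.22 log units; beyond the scatter), rests on one pair and on a limit, so its full size cannot be carried over. Compound 3 itself gives 1280 nM. A step of a 3.7-fold lower number from compound 3 to compound 4 (0.56 log units; beyond the scatter) is expected. The estimate for compound 4 is 350 nM, in the range 80 nM to 1500 nM.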

Compound 4, half-maximal inhibitory concentration: 670 nM
Estimate against measurement, compound 4: 1.9-fold (0.28 log units) below, and the stated range covers the measured number.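

In this assay, methyl in place of hydrogen on the aromatic nitrogen of the second core gives a 1.9-fold lower number from compound 3 to compound 4 (0.28 log units; within the scatter), so on this core the change cannot be told apart from repeat measurement. The size of the change therefore does not carry over from one core to the other in this series, and the two steps differ clearly: the same change on two cores in this assay, an at least 160-fold lower number (2.22 log units; beyond the scatter) from compound 2 to compound 1 and a 1.9-fold lower number (0.28 log units; within the scatter) from compound 3 to compound 4, at least 87-fold (1.94 log units) apart, beyond the scatter of two such steps Compound 2 gives >= 100000 nM, which is a limit of the assay and not a number, and two pairs alone do not show how large the first step is in full, which difference between the cores goes with the gap, or what the change would do on a third core.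

Open, going by these compounds, is how a group other than methyl would read on that aromatic nitrogen on either core, for instance ethyl, a longer chain, or a chain ending in an amine or a carboxylic acid. Also open is what the bromo groups contribute, as every compound shown carries two of them, so chloro or plain hydrogen in their place would be the next point of comparison.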